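This account rests on a few compounds, and the source may have more. Where it says the series, first, only, none or still open, it means among the compounds named here.

For the measured compounds named here, in a physicochemical assay for lipophilicity, at pH 7.4 (a higher number here means a more lipophilic compound, a lower number a more polar compound), compound 3 (`CC[C@@]1(c2ccccc2)COc2c(C(=O)NC)cc(C(=O)N[C@H]3[C@@H]4COC[C@@H]43)cc21`) stands highest of the three compounds measured so far, at 4.2. Compound 2 (`CNC(=O)c1cc(C(=O)N[C@H]2CC[C@H](O)CC2)cc2c1OC[C@@]2(C)c1ccccc1`) gives 3.3 and compound 1 (`CNC(=O)c1cc(C(=O)N[C@H]2[C@@H]3COC[C@@H]32)cc2c1OC[C@@]2(CO)c1ccccc1`) gives 2.4, both clearly lower. The next compound, compound 4 (`CNC(=O)c1cc(C(=O)N[C@H]2[C@@H]3COC[C@@H]32)cc2c1OC[C@@]2(C)c1ccccc1`), differs from compound 3 in one place: hydrogen in place of methyl on a saturated chain carbon bound to a saturated ring carbon. This is hydrogen in place of methyl on a saturated chain carbon bound to a saturated ring carbon, which, cut one bond further out, reads ethyl to methyl.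

Going by the values given here, only one measured step touches this place: a number 1.80 log units higher from compound 1 to compound 3 (beyond the scatter). That step is large, but it puts methyl in place of hydroxy rather than hydrogen in place of methyl, so it shows that the number can move at this place without fixing the size of the present change. Compound 4 shares its methyl with compound 2, which differs from it elsewhere and stands at 3.3. A smaller, downward step is therefore expected in this assay, estimated as a number 0.50 log units lower from compound 3 to compound 4 (beyond the scatter). Compound 4 is estimated at 3.7, with an expected range from 3.3 to 4.1.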

Compound 4, distribution coefficient: 3.7
Beside the measured number, compound 4's estimate shows no gap at the digits printed; the range from low to high includes it.
By their numbers in this assay, from the lowest: compound 1; then compound 2; then compound 4; then compound 3.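

With the hydrogen in place of methyl, this assay now has three groups compared at this one place on the same remainder of the structure: the number falls with the loss of the methyl (a number 0.50 log units lower from compound 3 to compound 4 (beyond the scatter)), and it rises by more when hydrogen replaces hydroxy (a number 1.30 log units higher from compound 1 to compound 4 (beyond the scatter)). The large earlier step from hydroxy to methyl therefore divides into two unequal parts, with the larger part lying between hydroxy and hydrogen and the smaller between hydrogen and methyl. For the compounds shown here, the result also gives the first reading at the other place of change, on the amide-type nitrogen, where the group of 6 heavy atoms stands in place of the group of 7 heavy atoms while the methyl stays the same (a number 0.40 log units higher from compound 2 to compound 4 (beyond the scatter)), although nothing measured here accounts for the size of any of these steps.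

The compounds shown leave open whether the order at this place would extend to a longer chain such as propyl, or how an amine would fall within it. They also leave open whether the step on the amide-type nitrogen would keep its size with hydroxy or ethyl on the shared core.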